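This account rests on a few compounds, and the source may have more. Where it says the series, first, only, none or still open, it means among the compounds named here.

Working notes on the series. Compound 1 `CC(C)[S+]([O-])CCCCN=C=S` and compound 2 `[O-][S+](CCCCN=C=S)Cc1ccccc1` are the two longer-chain members; the difference between their two cores is not broken down here. In a functional assay on A549 cells (Homo sapiens) for cytotoxicity, read by MTT assay, with a stated time of 72 h (on this read-out lower numbers stand for stronger inhibition and higher numbers for weaker inhibition), compound 1 gives 10400 nM and compound 2 gives 7410 nM, and these two values lie within the scatter of each other. Compound 3 `[O-][S+](CCCN=C=S)Cc1ccccc1` is reached from compound 2 by a group of 3 heavy atoms (1 carbon, 1 nitrogen, 1 sulfur; no ring) in place of a group of 4 heavy atoms (2 carbon, 1 nitrogen, 1 sulfur; no ring), on a saturated chain carbon, three bonds along the chain from a sulfur; in this assay compound 3 gives 11800 nM, which is a step of a 1.6-fold higher number from compound 2 to compound 3 (0.20 log units; within the scatter). Compound 4 `CC(C)[S+]([O-])CCCN=C=S` is not yet measured and is reached from compound 1 by the same change, (a group of 3 heavy atoms (1 carbon, 1 nitrogen, 1 sulfur; no ring) in place of a group of 4 heavy atoms (2 carbon, 1 nitrogen, 1 sulfur; no ring), on a saturated chain carbon, three bonds along the chain from a sulfur). For compound 4 a step of a 1.4-fold higher number from compound 1 to compound 4 (0.16 log units; within the scatter) is expected, resting on the observation that the same change gave a 1.6-fold higher number from compound 2 to compound 3 (0.20 log units; within the scatter). Compound 4 is thus estimated at 15000 nM in this assay, with a likely range from 7500 nM to 30000 nM.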

Compound 4, half-maximal inhibitory concentration: 16700 nM
Estimate against measurement, compound 4: 1.1-fold (0.05 log units) below, within the range that was stated.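

The change of the group of 4 heavy atoms to the group of 3 heavy atoms reads the same on the two cores in this assay: the same change on two cores in this assay, a 1.6-fold higher number (0.20 log units; within the scatter) from compound 2 to compound 3 and a 1.6-fold higher number (0.21 log units; within the scatter) from compound 1 to compound 4, 1.0-fold (0.00 log units) apart, within the scatter of two such steps

The new step is a 1.6-fold higher number from compound 1 to compound 4 (0.21 log units; within the scatter), and since both steps lie within the scatter, neither one alone shows that the change moves the read-out. Among the compounds shown here, the agreement therefore shows only that the change carries between these two cores without a visible difference, and it says nothing about any other core.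

Open, as far as these compounds go, is how a longer chain would read on either core. Also open, from the compounds shown here alone, is whether an amine or a carboxylic acid in place of the group of 3 heavy atoms would keep the read-out in this range.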